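Methoxy to chloro on the pendant aryl ring of a second core

The source may report more compounds than this note shows. Statements on the series, on what has been measured and on what is new or still open speak of the compounds shown alone.

Measured so far:
compound 1 `COc1ccc(C2=Nn3c(nnc3C(C)c3ccc(-c4ccccc4)c(F)c3)SC2)cc1` 4300 nM
compound 2 `COc1ccc(C2=Nn3c(nnc3C(C)c3ccc4cc(OC)ccc4c3)SC2)cc1` 8500 nM
compound 3 `CC(c1ccc(-c2ccccc2)c(F)c1)c1nnc2n1N=C(c1ccc(Cl)cc1)CS2` 3900 nM

Of the compounds shown here, three have been tested in a functional assay on Huh-7 cells (Homo sapiens) for inhibition, read by sulforhodamine B assay, with a stated time of 72 h; on this read-out lower numbers stand for stronger inhibition and higher numbers for weaker inhibition. Compound 1 `COc1ccc(C2=Nn3c(nnc3C(C)c3ccc(-c4ccccc4)c(F)c3)SC2)cc1` gives 4300 nM, and compound 3 `CC(c1ccc(-c2ccccc2)c(F)c1)c1nnc2n1N=C(c1ccc(Cl)cc1)CS2`, which carries chloro in place of methoxy on an aromatic carbon, gives 3900 nM; the step of a 1.1-fold lower number from compound 1 to compound 3 (0.04 log units; within the scatter) is small. Compound 2 `COc1ccc(C2=Nn3c(nnc3C(C)c3ccc4cc(OC)ccc4c3)SC2)cc1` gives 8500 nM; the difference between its core and the core of compound 1 is not broken down here. Compound 4 `COc1ccc2cc(C(C)c3nnc4n3N=C(c3ccc(Cl)cc3)CS4)ccc2c1` is not yet measured. It differs from compound 2 by chloro in place of methoxy on an aromatic carbon, the same change as from compound 1 to compound 3, made at the same place. Because a 1.1-fold lower number from compound 1 to compound 3 (0.04 log units; within the scatter) barely moved the number, compound 4 is expected to land close to compound 2 in this assay. The expected step is a 1.1-fold lower number from compound 2 to compound 4 (0.04 log units; within the scatter). Compound 4 is therefore estimated at 7800 nM, with a likely range from 3500 nM to 18000 nM.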

Compound 4, half-maximal inhibitory concentration: 5600 nM
Compound 4: the middle estimate sits 1.4-fold (0.14 log units) above what was measured; measured number inside the range.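

On a second core, the exchange of 4-methoxyphenyl for 4-chlorophenyl gives a 1.5-fold lower number from compound 2 to compound 4 (0.18 log units; within the scatter) in this assay, and this step agrees with the one seen on the first core: the same change on two cores in this assay, a 1.1-fold lower number (0.04 log units; within the scatter) from compound 1 to compound 3 and a 1.5-fold lower number (0.18 log units; within the scatter) from compound 2 to compound 4, 1.4-fold (0.14 log units) apart, within the scatter of two such steps. The change therefore carries across these two cores in a limited sense: on neither core does it move the number beyond the usual scatter of the measurement. This does not show that the change is without effect on other cores, and two pairs of this size cannot reveal a small difference between the two cores.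

The compounds shown leave open whether an amine or a carboxylic acid at the same place would move the number beyond the scatter. They also leave open how the methoxy-to-chloro change behaves on any third core.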